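From bromo to fluoro on the shared core

A few compounds are considered here, and "the series" means these few. Any claim that something is new, unique, unknown or untested is made for them only; others in the source may bear on it.

Measured in a functional assay on HUVEC cells (Homo sapiens) for inhibition, with a stated time of 4 days; a higher number here means a weaker inhibitor, a lower number a stronger inhibitor:
Compound 1 `COc1ccc(C(N)=O)cc1/C=C/c1ccccc1`: 2400 nM
Compound 2 `COc1ccc(C(N)=O)cc1/C=C/c1ccc(C(C)(C)C)cc1`: 370 nM
Compound 3 `COc1ccc(C(N)=O)cc1/C=C/c1ccc(Br)cc1`: 560 nM

Compound 3 cannot be told apart from compound 2, with a 1.5-fold higher number from compound 2 to compound 3 (0.18 log units; within the scatter), and it clearly lies under compound 1. Compound 4 `COc1ccc(C(N)=O)cc1/C=C/c1ccc(F)cc1` carries fluoro in place of bromo on an aromatic carbon, (fluoro in place of bromo on an aromatic carbon). Within the data shown here, no measured compound holds fluoro, so only the replacements of hydrogen bear on it: a 6.5-fold lower number from compound 1 to compound 2 (0.81 log units; beyond the scatter) and a 4.3-fold lower number from compound 1 to compound 3 (0.63 log units; beyond the scatter). Compound 4 is expected to keep only part of the gain seen for compound 3, so a small rise about at the edge of the scatter is expected in this assay. The estimated step is a 2.1-fold higher number from compound 3 to compound 4 (0.33 log units; beyond the scatter). For compound 4 the expected value is 1200 nM, with an estimated range of 500 nM to 2800 nM.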

Compound 4, half-maximal inhibitory concentration: 2100 nM
For compound 4 the middle estimate is 1.8-fold (0.24 log units) below the measured one; low and high end bracket the measured number.
By their numbers in this assay, from the lowest: compounds 2 and 3 (each within the scatter of the next); then compounds 4 and 1 (each within the scatter of the next).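

In this assay, putting a group in place of hydrogen at this position does not always give a gain: fluoro cannot be told apart from hydrogen (a 1.1-fold lower number from compound 1 to compound 4 (0.06 log units; within the scatter)). Bromo and tert-butyl both stay clearly apart from fluoro (a 3.8-fold higher number from compound 3 to compound 4 (0.57 log units; beyond the scatter); a 5.7-fold higher number from compound 2 to compound 4 (0.75 log units; beyond the scatter)), so the gain holds for these two groups and not for every group in this place. Nothing measured here accounts for the gap between fluoro and bromo. As far as these compounds go, whether chloro or methoxy on this aromatic carbon would side with bromo or with fluoro stays open, as does the outcome for an amine there.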